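This account rests on a few compounds, and the source may have more. Where it says the series, first, only, none or still open, it means among the compounds named here.

Three compounds have been measured in a functional assay on M14 cells (Homo sapiens) for cytotoxicity, read by MTT assay, with a stated time of 72 h; on this read-out higher numbers stand for weaker inhibition and lower numbers for stronger inhibition:

Compound 1, `COc1ccc(/C(=C\c2c[nH]c3ccc(OCc4ccccc4)cc23)C(=O)O)cc1`, gives 58400 nM.
Compound 2, `COc1ccc(Cn2cc(/C=C(/C(=O)O)c3ccccc3)c3cc(OCc4ccccc4)ccc32)cc1`, gives 64500 nM.
Compound 3, `COc1ccccc1/C(=C\c1cn(C(C)=O)c2ccc(OCc3ccccc3)cc12)C(=O)O`, reaches only a limit of > 100000 nM, not a number.

Compound 3 thus stands at the edge of what this assay can report; its result is the limit (the limit of > 100000 nM in this assay, at which 1 of the 3 values shown sits). Compounds 1 and 2 each give a measurable inhibition of cell growth, and their two values lie close to one another. Within the data shown here, no compound of the set is strongly cytotoxic on this read-out.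

Compound 4, `COc1cc(OC)cc(/C(=C\c2cn(C(C)=O)c3ccc(OCc4ccccc4)cc23)C(=O)O)c1`, keeps the whole of compound 3 except for one group: 3,5-dimethoxyphenyl in place of 2-methoxyphenyl on a double-bonded chain carbon bound to a carbonyl carbon and a double-bonded chain carbon. A 3,5-dimethoxyphenyl replaces the 2-methoxyphenyl at the chain carbon that carries the carboxylic acid. Among the measured compounds shown here, no measured pair of compounds mirrors this exchange, so there is no measured step to lean on. With compound 3 already at the limit, the exchange is expected to leave compound 4 in the same weak region, a step of an at least 1.1-fold lower number from compound 3 to compound 4 (0.04 log units; that floor lies within the scatter) that would not be beyond the usual scatter. Compound 4 is therefore estimated at 90000 nM, within a range of 40000 nM to 200000 nM, with a real chance that only a limit is reported.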

Compound 4, half-maximal inhibitory concentration: 94000 nM
The estimate for compound 4 lay 1.0-fold (0.02 log units) below the measured number; the range from low to high includes it.
By their numbers in this assay, from the lowest: compounds 1, 2 and 4 (each within the scatter of the next). At a limit, above all of these: compound 3.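

Swapping 2-methoxyphenyl for 3,5-dimethoxyphenyl at this chain carbon turns a result without a number into a measured one in this assay, and it shows that this position accepts the larger group, with its added oxygen, without losing the small measurable effect on the cells. Compound 3 reached only a limit, > 100000 nM, which is not a number. The change therefore reads as an at least 1.0-fold lower number from compound 3 to compound 4 (0.02 log units; that floor lies within the scatter), a floor that cannot establish a real gain, and the true size of the step stays unknown because one end of it is a limit: the limit of > 100000 nM in this assay, at which 1 of the 4 values shown sits.

On these data alone, it remains open whether a ring carrying an amine or a nitrile in place of the methoxy groups would bring a stronger effect at this position, or whether the number would stay in the same weak region. As far as these compounds go, it is also open whether the same exchange would act alike on the core of compound 1, where the ring nitrogen carries a hydrogen and no carbonyl group.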